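The source may hold more compounds than are shown below. What is called first, only, known or untested is meant among the compounds shown, and "the series" means these compounds.

Compound 2 `C=C1C2=C(C(=O)N1OC)[C@H](O)[C@@](C)(O)[C@H](CCCCC)O2` gives 19000 nM in an ADME assay on HEF cells (Homo sapiens) for cytotoxicity, read by MTT assay, with a stated time of 72 h (on this read-out lower numbers stand for stronger inhibition and higher numbers for weaker inhibition), the highest of the two numbers recorded, with compound 1 `C=C1C2=C(C(=O)N1OC)[C@H](OC(=O)CSc1nc3ccccc3s1)[C@@](C)(O)[C@H](CCCCC)O2` nearest at 11000 nM, a gap within the scatter. Compound 3 `C=C1C2=C(C(=O)N1OC)[C@H](OC(=O)CCCCCl)[C@@](C)(O)[C@H](CCCCC)O2` differs from compound 2 by (4-chlorobutyl)carbonyl in place of hydrogen on an oxygen on a saturated carbon. Among the compounds with values here, no step between measured compounds is available for this change, and the two measured numbers sit within the scatter of each other. The step of a 1.5-fold lower number from compound 2 to compound 3 (0.16 log units; within the scatter) is therefore expected to be small, if anything toward a slightly lower number, and not beyond the scatter. Compound 3 is estimated at 13000 nM, with a range of 5000 nM to 35000 nM.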

Compound 3, half-maximal inhibitory concentration: 11000 nM
The estimate for compound 3 lay 1.2-fold (0.07 log units) above the measured number, within the range that was stated.
By their numbers in this assay, from the lowest: compounds 1, 3 and 2 (each within the scatter of the next).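

The step from hydroxy to ((4-chlorobutyl)carbonyl)oxy on this oxygen reads a 1.7-fold lower number from compound 2 to compound 3 (0.24 log units; within the scatter) and stays within the scatter, as does the exchange of (1,3-benzothiazol-2-yl)sulfanyl for 3-chloropropyl, which reads no change at the digits printed from compound 1 to compound 3 (within the scatter) and so does not separate these two ester side chains. Nothing measured on these compounds bears on the reason for either step.

Still open, from the compounds shown here alone, is whether an ester chain ending in an amine or a carboxylic acid instead of chlorine would give a step beyond the scatter. The same question holds for a longer chain.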